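Changing the Ring on the Carbonyl Carbon

The source may hold more compounds than are shown below. What is called first, only, known or untested is meant among the compounds shown, and "the series" means these compounds.

Of the compounds shown here, three with a shared core have been measured, differing mainly in the ring attached to the carbonyl carbon. Compound 1 `COc1cc2ncnc(NNC(=S)NC(=O)c3ccccc3C)c2cc1OC` gives 11100 nM in a functional assay on MGC-803 cells (Homo sapiens) for cytotoxicity, read by MTT assay, with a stated time of 72 h; a lower number here means a stronger inhibitor, a higher number a weaker inhibitor. Compound 2 `COc1cc2ncnc(NNC(=S)NC(=O)c3ccc(F)cc3)c2cc1OC` gives 8300 nM in this assay, the second highest of the three numbers. Compound 3 `Cc1ccc(C(=O)NC(=S)NNc2ncnc3ccccc23)cc1` gives 3760 nM in this assay. Compound 4 `COc1cc2ncnc(NNC(=S)NC(=O)c3ccccc3Cl)c2cc1OC` is not yet measured; it differs from compound 2 by 2-chlorophenyl in place of 4-fluorophenyl on a carbonyl carbon. Among the compounds with values here, the one step that bears on this change is a 1.3-fold lower number from compound 1 to compound 2 (0.13 log units; within the scatter), where a different ring on the same carbonyl carbon left the number almost unchanged. A step within the scatter is therefore expected, a 1.1-fold higher number from compound 2 to compound 4 (0.04 log units; within the scatter). Compound 4 is estimated at 9000 nM, in a range from 4000 nM to 20000 nM.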

Compound 4, half-maximal inhibitory concentration: 6440 nM
Estimate against measurement, compound 4: 1.4-fold (0.15 log units) above, within the range that was stated.
By their numbers in this assay, from the lowest: compounds 3, 4, 2 and 1 (each within the scatter of the next, the first and the last beyond it).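

In this assay, putting 2-chlorophenyl in place of 4-fluorophenyl on the carbonyl carbon gives a 1.3-fold lower number from compound 2 to compound 4 (0.11 log units; within the scatter), so a second ring change at this position also makes no readable difference. Chloro in place of methyl on an aromatic carbon, a change to a single group on the ring, gives a 1.7-fold lower number from compound 1 to compound 4 (0.24 log units; within the scatter), which again cannot be told from repeat variation. Nothing measured here explains why these rings read alike. Still open, from the compounds shown here alone, is whether a phenyl ring carrying an amine or a carboxylic acid would read differently, and whether a longer chain in place of the ring would do so.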